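Swapping the hydroxyphenyl for a bromophenyl at the hydrazone carbon

This account rests on a few compounds, and the source may have more. Where it says the series, first, only, none or still open, it means among the compounds named here.

Compound 2 `Oc1ccc(/C=N/Nc2nc3ccccc3nc2Cc2ccccc2)cc1` gives 3.4 nM in an assay on isolated protein for inhibition of Amine oxidase [flavin-containing] A (Homo sapiens), read by spectrophotometry (a higher number here means a weaker inhibitor, a lower number a stronger inhibitor), and stands lowest of the two numbers recorded; its nearest neighbour, compound 1 `COc1ccccc1/C=N/Nc1nc2ccccc2nc1Cc1ccccc1`, gives 83 nM in this assay. Compound 3 `Brc1cccc(/C=N/Nc2nc3ccccc3nc2Cc2ccccc2)c1` differs from compound 2 by 3-bromophenyl in place of 4-hydroxyphenyl on a carbon with a double bond to nitrogen. For the measured compounds named here, the only step that bears on this change is a 24-fold lower number from compound 1 to compound 2 (1.39 log units; beyond the scatter), where the aryl group on that carbon was altered. A change of the same aryl in compound 3 is therefore expected to shift the number upward, with an estimated 15-fold higher number from compound 2 to compound 3 (1.17 log units; beyond the scatter). Compound 3 is estimated at 50 nM, within a range from 10 nM to 250 nM.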

Compound 3, half-maximal inhibitory concentration: 9.8 nM
Beside the measured number, compound 3's estimate is 5.1-fold (0.71 log units) above it, outside the stated range (below it).
By their numbers in this assay, from the lowest: compound 2; then compound 3; then compound 1.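

Replacing 4-hydroxyphenyl with 3-bromophenyl on the carbon with a double bond to nitrogen brings only a modest rise in this assay (a 2.9-fold higher number from compound 2 to compound 3 (0.46 log units; beyond the scatter)), so a low number here does not depend on the hydroxyl. The same 3-bromophenyl still reads well below the 2-methoxyphenyl (an 8.5-fold lower number from compound 1 to compound 3 (0.93 log units; beyond the scatter)), leaving compound 1 the weakest of the three. Nothing available explains these steps.

Going by these compounds, whether the identity of the ring substituent or its place on the ring drives these differences stays open, as each aryl group differs in both. On these data alone, how an amine or a carboxylic acid on this phenyl would read also remains open.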